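From 2-chlorophenyl to 3-chlorophenyl on a single anchor

The compounds below may be only part of what the source reports. "The series", "measured", "known", "first", "only" and "open" are said of these compounds alone.

Three related compounds have entries in a functional assay on HCT-116 cells (Homo sapiens) for cytotoxicity, read by a luciferase reporter and CellTiter-Glo, with a stated time of 72 h (on this read-out higher numbers stand for weaker inhibition and lower numbers for stronger inhibition), yet only one of them carries a number. Compound 1 (`COc1cccc(C2=NN(c3cccc(Cl)c3)C(c3cccc(Cl)c3)C2)c1`) stands as "not determined" (no result reported) in the record, and compound 2 (`COc1ccccc1C1=NN(c2cccc(Cl)c2)C(c2ccc(Cl)cc2)C1`) stands as "not determined" (no result reported) in the same way, so neither offers a comparison. Within the data shown here, compound 3 (`COc1ccccc1C1=NN(c2ccccc2Cl)C(c2cccc(Cl)c2)C1`) gives 1900 nM in this assay, the only number available, and it therefore cannot be ranked against anything.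

The next compound to be measured is compound 4 (`COc1ccccc1C1=NN(c2cccc(Cl)c2)C(c2cccc(Cl)c2)C1`), which has 3-chlorophenyl in place of 2-chlorophenyl on an amine nitrogen in a ring. The two share the same atoms, joined differently: 3-chlorophenyl in place of 2-chlorophenyl on an amine nitrogen in a ring. Among the measured compounds shown here, compounds 1 and 2 carry 3-chlorophenyl at that place too, but they supply no number, so no measured step shows what this exchange does. With only compound 3 at 1900 nM as an anchor, no direction is firmly supported. The expected 1.3-fold lower number from compound 3 to compound 4 (0.10 log units; within the scatter) is small and stays within the usual scatter of repeated measurements. For compound 4 the expected value is about 1500 nM with an estimated range from 400 nM to 5500 nM in this measurement.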

Compound 4, half-maximal inhibitory concentration: 1600 nM
The estimate for compound 4 lay 1.1-fold (0.03 log units) below the measured number; low and high end bracket the measured number.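

In this assay the exchange of 2-chlorophenyl for 3-chlorophenyl on an amine nitrogen in a ring gives a 1.2-fold lower number from compound 3 to compound 4 (0.07 log units; within the scatter), so the two compounds cannot be told apart on this read-out. Among these compounds, the earlier entries offered a single number and nothing to set it against, whereas this pair supplies the first measured step at this place and shows that the two chlorophenyl arrangements read alike here, at least with the 3-chlorophenyl and 2-methoxyphenyl groups of the shared core held fixed. Nothing measured alongside these numbers bears on why the exchange leaves the reading where it is.

The compounds shown leave open how this place responds to anything other than a chlorophenyl group, such as an unsubstituted phenyl, a 4-chlorophenyl, a pyridine or a phenyl ring carrying an amine or a carboxylic acid. They also leave open whether the same exchange would read alike with a different group in place of the 2-methoxyphenyl, since compounds 1 and 2 carry no number to test it.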